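The source may hold more compounds than are shown below. What is called first, only, known or untested is meant among the compounds shown, and "the series" means these compounds.

Compound 1 `COc1cc(-n2cnc3ccc(-c4ccc([N+](=O)[O-])cc4)cc32)cc(OC)c1OC` gives 8940 nM in a functional assay on A549 cells (Homo sapiens) for antiproliferative activity, read by MTT assay, with a stated time of 72 h; on this read-out lower numbers stand for stronger inhibition and higher numbers for weaker inhibition. Compound 2 `COc1cc(-n2cnc3ccc(-c4ccc(Cl)cc4)cc32)cc(OC)c1OC` reaches only a limit of this assay, > 10000 nM. Compound 3 `COc1cc(-n2cnc3ccc(-c4cccc(C)c4)cc32)cc(OC)c1OC` gives 3820 nM.

Among the three, compound 3 has the lowest number that is a number at all, and the nearest measured neighbour is compound 1, separated by the step of a 2.3-fold lower number from compound 1 to compound 3 (0.37 log units; beyond the scatter). Compound 4 `COc1cc(-n2cnc3ccc(-c4ccc(C(C)=O)cc4)cc32)cc(OC)c1OC` differs from compound 3 in one place: 4-acetylphenyl in place of 3-methylphenyl on an aromatic carbon. The measured steps that bear on this change both ran the other way, toward the 3-methylphenyl: a 2.3-fold lower number from compound 1 to compound 3 (0.37 log units; beyond the scatter) and an at least 2.6-fold lower number from compound 2 to compound 3 (0.41 log units; beyond the scatter). Both were modest lowerings of the number. Compound 4 returns to a group of the 4-nitrophenyl and 4-chlorophenyl kind, the 4-acetylphenyl, so a modest rise in the number, back toward the level of compound 1, is expected, with the limit seen for compound 2 as a possible outcome. The estimated step is a 1.8-fold higher number from compound 3 to compound 4 (0.26 log units; within the scatter). Compound 4 is therefore expected to give about 7000 nM in this assay, between 3000 nM and 18000 nM.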

Compound 4, half-maximal inhibitory concentration: 2510 nM
Estimate against measurement, compound 4: 2.8-fold (0.45 log units) above; the measured number lies below the stated range.
By their numbers in this assay, from the lowest: compounds 4 and 3 (each within the scatter of the next); then compound 1. At a limit, above all of these: compound 2.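

In this assay, among these compounds, putting 4-acetylphenyl in place of 3-methylphenyl at this position of the shared core gives a 1.5-fold lower number from compound 3 to compound 4 (0.18 log units; within the scatter), so the 3-methylphenyl is not the only group that reaches this level, and a phenyl group substituted at its 4-position can do so too. The substituent on that phenyl ring therefore matters, as acetyl in place of nitro gives a 3.6-fold lower number from compound 1 to compound 4 (0.55 log units; beyond the scatter) and acetyl in place of chloro gives an at least 3.9-fold lower number from compound 2 to compound 4 (0.60 log units; beyond the scatter). The second of these steps is only a floor, because compound 2 stands at a limit of the assay: the limit of > 10000 nM in this assay, at which 1 of the 4 values shown sits.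

On these data alone, it remains open whether an amine or a carboxylic acid in place of the acetyl would keep the number at the level of compound 3 and compound 4 or raise it. As far as these compounds go, it is also open whether any group at this position can bring the number clearly lower than both of them.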